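From 4-fluorobenzyl to 4-methoxybenzyl in compound 3

The compounds below may be only part of what the source reports. "The series", "measured", "known", "first", "only" and "open" are said of these compounds alone.

Values from a functional assay on HepG2 cells (Homo sapiens) for antiproliferative activity, read by MTT assay, with a stated time of 48 h (on this read-out lower numbers stand for stronger inhibition and higher numbers for weaker inhibition), follow
Compound 1 `Fc1ccc(CNc2ccc3ncnc(Nc4cccc(Br)c4)c3c2)cc1` gives 1770 nM
Compound 2 `Fc1ccc(CNc2ccc3ncnc(Nc4cccc(Cl)c4)c3c2)cc1` gives 2690 nM
Compound 3 `COc1ccc(CNc2ccc3ncnc(Nc4cccc(Cl)c4)c3c2)cc1` has not yet been measured

Compound 2 sits within the scatter of compound 1, so no order can be read between the two numbers. Compound 3 differs from compound 2 by methoxy in place of fluoro on an aromatic carbon in one place, with methoxy in place of fluoro on an aromatic carbon, para to a large group. Going by the values given here, the only measured step is a 1.5-fold higher number from compound 1 to compound 2 (0.18 log units; within the scatter) and it concerns chloro in place of bromo on an aromatic carbon, elsewhere in the structure. Among the compounds with values here, that step says nothing direct about exchanging fluoro for methoxy, and the data hold no measured example of this exchange. With no evidence for a direction, no shift beyond the scatter is expected, though the uncertainty is wide. The expected change is a 1.1-fold lower number from compound 2 to compound 3 (0.03 log units; within the scatter) in this assay and this is an estimate only. Compound 3 is estimated at 2500 nM in the expected read-out. The expected range for compound 3 runs from 1000 nM to 6000 nM on this estimate.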

Compound 3, half-maximal inhibitory concentration: 5260 nM
Compound 3: middle estimate off by 2.1-fold (0.32 log units), on the low side; low and high end bracket the measured number.
By their numbers in this assay, from the lowest: compounds 1, 2 and 3 (each within the scatter of the next, the first and the last beyond it).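

Compound 3 alone carries a change at this position, as the earlier pair differed only in the halogen elsewhere in the structure. In this assay, methoxy in place of fluoro on an aromatic carbon, para to a large group, gives a 2.0-fold higher number from compound 2 to compound 3 (0.29 log units; within the scatter), so this exchange, which puts 2 heavy atoms and 1 hydrogen-bond acceptor where fluoro had 1 heavy atom and no acceptor, does not move the number beyond the scatter. No measurement offered here bears on how this position acts on the read-out, and none speaks to what lies behind this small step.

Open, from the compounds shown here alone, is whether an amine, a carboxylic acid or a longer chain such as ethoxy in the same place would also stay within the scatter of compound 2, since one exchange gives no trend for this position. Also open, going by these compounds, is whether methoxy in place of fluoro would read the same with bromo on the other side of the molecule, as in compound 1, or whether the two changes depend on each other.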